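The source may hold more compounds than are shown below. What is called first, only, known or untested is meant among the compounds shown, and "the series" means these compounds.

In a physicochemical assay for lipophilicity, at pH 7.4 (a lower number here means a more polar compound, a higher number a more lipophilic compound), compound 3 (`CC(C)CN(C1CCc2ccc(F)cc21)S(=O)(=O)c1ccc2c(c1)C(O)CC(C1CCOCC1)O2`) gives 3.94, the middle of the three measured numbers: compound 2 (`Cc1cc(C(O)(C(F)(F)F)C(F)(F)F)ccc1N(CC(C)C)S(=O)(=O)c1ccc2c(c1)C(O)CC(C1CCOCC1)O2`) stands higher at 4.37, and compound 1 (`CCS(=O)(=O)c1ccc(CN(CC(C)C)S(=O)(=O)c2ccc3c(c2)C(O)CC(C2CCOCC2)O3)nc1`) stands lower at 1.42. Compound 4 (`Cc1ccc(N(CC(C)C)S(=O)(=O)c2ccc3c(c2)C(O)CC(C2CCOCC2)O3)c(C)c1`) differs from compound 3 by one change on a sulfonamide nitrogen: 2,4-dimethylphenyl in place of 6-fluoro-2,3-dihydro-1H-inden-1-yl on a sulfonamide nitrogen. Both groups carry no net charge. Among the measured compounds shown here, the only measured step at this nitrogen is a number 2.52 log units higher from compound 1 to compound 3 (beyond the scatter), which is large and beyond the scatter. However, that step involved the (5-(ethylsulfonyl)pyridin-2-yl)methyl group, which plays no part in this exchange, so it offers little guide to size. No shift beyond the scatter is therefore expected, a number 0.11 log units higher from compound 3 to compound 4 (within the scatter). For compound 4 the estimated value is 4.05, with an expected range of 3.6 to 4.5.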

Compound 4, distribution coefficient: 4.19
Estimate against measurement, compound 4: 0.14 log units below, and the stated range covers the measured number.
By their numbers in this assay, from the lowest: compound 1; then compounds 3, 4 and 2 (each within the scatter of the next, the first and the last beyond it).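

In this assay, 2,4-dimethylphenyl and 6-fluoro-2,3-dihydro-1H-inden-1-yl on the sulfonamide nitrogen are not told apart (a number 0.25 log units higher from compound 3 to compound 4 (within the scatter)), whereas (5-(ethylsulfonyl)pyridin-2-yl)methyl stands apart (a number 2.77 log units higher from compound 1 to compound 4 (beyond the scatter)). On the aromatic carbon, methyl in place of 2,2,2-trifluoro-1-hydroxy-1-(trifluoromethyl)ethyl also makes no difference beyond the scatter (a number 0.18 log units lower from compound 2 to compound 4 (within the scatter)). No evidence is at hand to explain these steps. The compounds shown leave open how a carboxylic acid or an amine in place of that methyl would read in this assay, and whether the ethylsulfonyl or the pyridine part accounts for the gap to compound 1.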